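Ester for Weinreb-type amide in a nucleoside urea series

A few compounds are considered here, and "the series" means these few. Any claim that something is new, unique, unknown or untested is made for them only; others in the source may bear on it.

Measured compounds:
compound 1 `CCOC(=O)C[C@H]1[C@@H](O[Si](C)(C)C(C)(C)C)[C@H](n2cnc3c(NC(=O)Nc4ccccc4)ncnc32)O[C@@H]1COC(=O)NC` — 6.93 nM
compound 2 `CNC(=O)NC[C@H]1O[C@@H](n2cnc3c(NC(=O)Nc4ccccc4)ncnc32)[C@H](O[Si](C)(C)C(C)(C)C)[C@@H]1CC(=O)N(C)OC` — 9.35 nM

In a functional assay on A549 cells (Homo sapiens) for antiproliferative activity (a higher number here means a weaker inhibitor of growth, a lower number a stronger inhibitor of growth), compound 2 gives 9.35 nM, the higher of the two numbers; compound 1 lies within the scatter of it. Compound 3 `CCOC(=O)C[C@H]1[C@@H](O[Si](C)(C)C(C)(C)C)[C@H](n2cnc3c(NC(=O)Nc4ccccc4)ncnc32)O[C@@H]1CNC(=O)NC` differs from compound 2 by ethoxy in place of methoxy(methyl)amino on a carbonyl carbon. Compound 1 also carries the ethoxy on its carbonyl carbon, and in this assay compound 1 gives 6.93 nM, close to compound 2. Because compound 1 gives 6.93 nM within the scatter, no step beyond the scatter is expected a 1.2-fold lower number from compound 2 to compound 3 (0.07 log units; within the scatter). Compound 3 is estimated at 8 nM (range 3 nM to 20 nM).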

Compound 3, concentration for 50% growth inhibition: 4.18 nM
Compound 3: the middle estimate sits 1.9-fold (0.28 log units) above what was measured; the range from low to high includes it.
By their numbers in this assay, from the lowest: compounds 3, 1 and 2 (each within the scatter of the next, the first and the last beyond it).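

In this assay, ethoxy in place of methoxy(methyl)amino on the carbonyl carbon gives a 2.2-fold lower number from compound 2 to compound 3 (0.35 log units; beyond the scatter), a modest step and the only one in this set beyond the scatter. By contrast, (methylcarbamoyl)amino in place of (methylcarbamoyl)oxy on the saturated chain carbon gives a 1.7-fold lower number from compound 1 to compound 3 (0.22 log units; within the scatter), so that change is not resolved here. Nothing available explains the step at the carbonyl carbon.

Open, from the compounds shown here alone, is how a carboxylic acid or a primary amide would read at this carbonyl carbon. Also open, going by these compounds, is whether a longer chain in place of ethoxy would hold the number.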